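The compounds below may be only part of what the source reports. "The series", "measured", "known", "first", "only" and "open" are said of these compounds alone.

Working notes on the series, step from compound 1 to compound 4.

Compound 1 `CCCSc1nc(N/N=C/c2ccc(Cl)cc2)c2nnn(Cc3ccccc3)c2n1` is the reference point. In a functional assay on MCF7 cells (Homo sapiens) for antiproliferative activity, read by MTT assay, with a stated time of 72 h (a higher number here means a weaker inhibitor, a lower number a stronger inhibitor), compound 1 is reported only as a limit of the assay, > 64000 nM, so its position on the numbers is an upper bound rather than a value (the limit of > 64000 nM in this assay, at which 1 of the 3 values shown sits). Two measured compounds leave the same part of the molecule altered: compound 2 `CCCSc1nc(N/N=C/c2ccc(N(C)C)cc2)c2nnn(Cc3ccccc3)c2n1` gives 12200 nM in this assay, and compound 3 `CCCSc1nc(N/N=C/c2c(O)ccc3ccccc23)c2nnn(Cc3ccccc3)c2n1` gives 6400 nM. The step of an at least 5.2-fold lower number from compound 1 to compound 2 (0.71 log units; beyond the scatter) and the step of an at least 10-fold lower number from compound 1 to compound 3 (1.00 log units; beyond the scatter) both run downward from the limit, whereas a 1.9-fold lower number from compound 2 to compound 3 (0.28 log units; within the scatter) is within the scatter.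

Compound 4 `CCCSc1nc(N/N=C(\C)c2ccc(Br)cc2)c2nnn(Cc3ccccc3)c2n1` differs from compound 1 by a group of 10 heavy atoms (8 carbon, 1 nitrogen, 1 bromine; one six-membered aromatic ring of carbon only) in place of a group of 9 heavy atoms (7 carbon, 1 nitrogen, 1 chlorine; one six-membered aromatic ring of carbon only), on a nitrogen on an aromatic ring. The halogen changes from chlorine to bromine and a methyl enters; the hydrazone linkage and the benzyl-bearing core are kept. For the measured compounds named here, the measured steps that bear on this change all replaced the chlorophenyl group by a quite different aromatic group, so they give no direct guide to a halogen swap; no step in the set isolates the methyl. Expected: compound 4 stays close to compound 1, an at least 1.0-fold lower number from compound 1 to compound 4 (0.02 log units; that floor lies within the scatter), with a fair chance that this assay again reports only a limit. The estimate for compound 4 in this assay is 60000 nM, with a range from 15000 nM to 200000 nM.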

Compound 4, half-maximal inhibitory concentration: 13000 nM
Compound 4: middle estimate off by 4.6-fold (0.66 log units), on the high side; the whole stated range lies above it.
By their numbers in this assay, from the lowest: compounds 3, 2 and 4 (each within the scatter of the next, the first and the last beyond it). At a limit, above all of these: compound 1.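

The change on a nitrogen on an aromatic ring keeps a halogen and a six-membered aromatic ring of carbon only, yet in this assay it still brings an at least 4.9-fold lower number from compound 1 to compound 4 (0.69 log units; beyond the scatter). For the compounds shown here, a halogen on that ring therefore does not by itself hold a compound at the limit, and the earlier steps, which all removed the halogen, could not show this. Compound 1 stands at a limit and not a number, so the size of this step is only a floor: the limit of > 64000 nM in this assay, at which 1 of the 4 values shown sits.

Whether the bromine or the added methyl carries the step stays open, as no compound shown holds one without the other. Also open, from the compounds shown here alone, is how this assay reads a methoxy group or a carboxylic acid in place of the bromine.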